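Amide aryl replacement: pyrazole to phenethyl on the carbonyl

The compounds below may be only part of what the source reports. "The series", "measured", "known", "first", "only" and "open" are said of these compounds alone.

The shared core carries a propyl group, a methoxy group and a primary carboxamide; the variation sits on the carbonyl carbon of the acylamino group. Compound 1 `CCCn1c(NC(=O)c2ccccn2)nc2cc(C(N)=O)cc(OC)c21` bears pyridin-2-yl there. In an assay for activation of interferon regulatory factor 3 (Homo sapiens), read by a luciferase reporter, with a stated time of 20 h (a lower number here means that less compound is needed, a higher number that more compound is needed for the effect), compound 1 gives > 100000 nM, which is a limit of the assay and not a number. Compound 2 `CCCn1c(NC(=O)c2cccnn2)nc2cc(C(N)=O)cc(OC)c21` bears pyridazin-3-yl. In this assay compound 2 gives > 100000 nM, again a limit. Compound 3 `CCCn1c(NC(=O)c2ccnn2CC)nc2cc(C(N)=O)cc(OC)c21` bears 1-ethyl-1H-pyrazol-5-yl. In this assay compound 3 gives > 100000 nM, also a limit. The three steps between these compounds, a step that the two limits leave unreadable from compound 1 to compound 2, a step that the two limits leave unreadable from compound 1 to compound 3 and a step that the two limits leave unreadable from compound 2 to compound 3, are unreadable in size because of the limit of > 100000 nM in this assay, at which 3 of the 3 values shown sit. Compound 3 thus stands at the limit together with both other measured compounds, and no order among them can be read.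

Compound 4 `CCCn1c(NC(=O)CCc2ccccc2)nc2cc(C(N)=O)cc(OC)c21` differs from compound 3 in one place: phenethyl in place of 1-ethyl-1H-pyrazol-5-yl on a carbonyl carbon. Among the compounds with values here, none of the measured steps gives a readable size for any change on this carbonyl carbon, so neither direction nor size can be taken from them. The expected step of a number no higher from compound 3 to compound 4 (the limit leaves the size open) is set at no change. Compound 4 is expected to give 100000 nM in this assay, within 30000 nM to 300000 nM, most likely reported again as a limit.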

Compound 4, half-maximal effective concentration: > 100000 nM
Compound 4: no number, only a limit; the forecaster's own chance of this, stated with the estimate: 80%; the middle value sits exactly at the limit.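

In this assay compound 4 gives > 100000 nM, a limit of the assay and not a number. No step from compound 1, compound 2 or compound 3 to compound 4 can be read, because all four compounds share that limit: the limit of > 100000 nM in this assay, at which 4 of the 4 values shown sit.

The compounds shown leave open whether any group on this carbonyl carbon gives a readable value, and how these four groups rank.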